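A Pyridine Ring Replaces the Benzyl Ring

This account rests on a few compounds, and the source may have more. Where it says the series, first, only, none or still open, it means among the compounds named here.

Compound 1 `O=C(Nc1ccc(N(CC2CC2)CC2CC2)cc1Cl)c1cc(Cl)ccc1O`: 12800 nM
Compound 2 `O=C(Nc1ccc(NCc2ccc(Cl)cc2)cc1Cl)c1cc(Cl)ccc1O`: 59700 nM
Compound 3 `O=C(Nc1ccc(NCc2ccc(C(F)(F)F)cc2)cc1Cl)c1cc(Cl)ccc1O`: 62700 nM

In an ADME assay on A549 cells (Homo sapiens) for cytotoxicity, read by resazurin assay, with a stated time of 48 h (on this read-out higher numbers stand for lower toxicity in this test and lower numbers for higher toxicity in this test), compound 3 gives the highest number of the three measured compounds. Compound 2 lies within the scatter of it, whereas compound 1 sits clearly lower, as the step of a 4.7-fold higher number from compound 1 to compound 2 (0.67 log units; beyond the scatter) shows. Compound 4 `O=C(Nc1ccc(NCc2cnccc2Cl)cc1Cl)c1cc(Cl)ccc1O` differs from compound 3 at a single point: 4-chloropyridin-3-yl in place of 4-(trifluoromethyl)phenyl on a saturated chain carbon bound to a nitrogen on an aromatic ring. The step that most resembles this change is a 1.1-fold higher number from compound 2 to compound 3 (0.02 log units; within the scatter), in which a group on the same benzyl ring was exchanged without leaving the scatter. Among the measured compounds shown here, no measured step tells what a ring nitrogen does here. Compound 4 is therefore expected to show a step of a 1.1-fold lower number from compound 3 to compound 4 (0.06 log units; within the scatter), with an estimate of 55000 nM and a range from 28000 nM to 105000 nM.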

Compound 4, half-maximal cytotoxic concentration: 126000 nM
For compound 4 the middle estimate is 2.3-fold (0.36 log units) below the measured one; the whole stated range lies below it.
By their numbers in this assay, from the lowest: compound 1; then compounds 2, 3 and 4 (each within the scatter of the next, the first and the last beyond it).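

In this assay, among the compounds shown here, a ring nitrogen is tolerated on this benzyl ring: 4-chloropyridin-3-yl in place of 4-(trifluoromethyl)phenyl gives a 2.0-fold higher number from compound 3 to compound 4 (0.30 log units; within the scatter), while in place of 4-chlorophenyl it gives a 2.1-fold higher number from compound 2 to compound 4 (0.32 log units; beyond the scatter), the first change on this ring to pass the scatter. Set against the bis(cyclopropylmethyl)amino group, the ((4-chloropyridin-3-yl)methyl)amino group gives a 9.8-fold higher number from compound 1 to compound 4 (0.99 log units; beyond the scatter), the widest step in the series. Nothing measured here explains these steps. As far as these compounds go, it remains open whether the ring nitrogen or the placing of the chloro drives them, and how a plain pyridin-3-yl or a 4-methoxypyridin-3-yl group would read.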